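The source may report more compounds than this note shows. Statements on the series, on what has been measured and on what is new or still open speak of the compounds shown alone.

Measured in a functional assay on PC-3 cells (Homo sapiens) for antiproliferative activity, read by MTT assay, with a stated time of 24 h; a lower number here means a stronger inhibitor, a higher number a weaker inhibitor:

Compound 1 `COc1ccc(-c2noc(-c3ccccc3)n2)cc1OC1CCCC1`: > 1000000 nM, a limit.
Compound 2 `COc1ccc(-c2noc(-c3ccc(F)cc3)n2)cc1OC1CCCC1`: > 1000000 nM, a limit.

Compound 2 has no numerical value in this assay, only a limit. Going by the values given here, the one other value, that of compound 1, is also a limit. Both compounds sit at the limit of > 1000000 nM in this assay, at which 2 of the 2 values shown sit.

Compound 3 `COc1ccc(-c2noc(-c3ccc(O)cc3)n2)cc1OC1CCCC1` has hydroxy in place of fluoro on an aromatic carbon, para to a large group, so that 4-fluorophenyl becomes 4-hydroxyphenyl: hydroxy in place of fluoro on an aromatic carbon.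

Among the compounds with values here, the one measured step that bears on this change is a step that the two limits leave unreadable from compound 1 to compound 2, with fluoro in place of hydrogen on an aromatic carbon. Both ends of that step are limits, and it offers no size to carry over. Within the data shown here, no hydroxy compound has yet been measured. Among the measured compounds shown here, no step of definite size or direction can therefore be expected in this assay, and a further limit is the most likely result, with some chance of a readable number.

The expected change is a number no higher from compound 2 to compound 3 (the limit leaves the size open). For compound 3 the estimated half-maximal inhibitory concentration is 1000000 nM, with an expected range from 100000 nM to 2000000 nM.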

Compound 3, half-maximal inhibitory concentration: 162000 nM
Compound 3: middle estimate off by 6.2-fold (0.79 log units), on the high side; low and high end bracket the measured number.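

In this assay, compound 3 gives the first readable number in the series, while the other two compounds remain at a limit: the limit of > 1000000 nM in this assay, at which 2 of the 3 values shown sit.

Hydroxy on this aromatic carbon, para to a large group, gives a change beyond the scatter against both neighbours: an at least 6.1-fold lower number from compound 2 to compound 3 (0.79 log units; beyond the scatter) for hydroxy in place of fluoro, and an at least 6.1-fold lower number from compound 1 to compound 3 (0.79 log units; beyond the scatter) for hydroxy in place of hydrogen. This position can therefore affect the read-out in this assay, although both steps give only a minimum size, and the step between compound 1 and compound 2 cannot be read.

The change adds one hydrogen-bond donor and one hydrogen-bond acceptor, but the compounds shown do not separate the contribution of either count from that of hydroxy as a whole. From the compounds shown here alone, whether an amine, a methoxy group or a carboxylic acid at the same position would also give a readable number remains open, as does whether hydroxy at another position on this ring would do so.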